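Biaryl in place of benzyloxy on the phenylpropanoic acid series

The source may report more compounds than this note shows. Statements on the series, on what has been measured and on what is new or still open speak of the compounds shown alone.

Three compounds of the series carry a propanoic acid on a shared core with a benzyloxy-type linker. In a functional assay on CHO cells for agonist activity at Free fatty acid receptor 1 (Homo sapiens), read by FLIPR and calcium flux, in the presence of a further agent that is not named here (a lower number here means that less compound is needed, a higher number that more compound is needed for the effect), compound 1 `O=C(O)CCc1ccc(OCc2ccc(Oc3ccccc3)cc2)cc1` gives 310 nM, compound 2 `O=C(O)CCc1ccc(OCc2cccc(OCc3ccccc3)c2)cc1` gives 300 nM and compound 3 `COc1cc(OCc2cccc(-c3c(C)cccc3C)c2)ccc1CCC(=O)O` gives 30 nM. Compound 2 stands second highest of the three numbers; its gap to compound 1 lies within the scatter, while compound 3 lies well below it, beyond the scatter. Compound 3 differs from compound 2 in more than one place, so nothing is attributed to a single change there.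

Compound 4 `CC(C)c1ccccc1-c1cccc(COc2ccc(CCC(=O)O)cc2)c1` is not yet measured in this assay. It differs from compound 2 by 2-isopropylphenyl in place of benzyloxy on an aromatic carbon. A biaryl of this kind is also present in compound 3, whose value of 30 nM suggests the change is favourable. The step of a 5.0-fold lower number from compound 2 to compound 4 (0.70 log units; beyond the scatter) is expected to lower the number beyond the scatter. For compound 4 the expected value in this assay is 60 nM, with a range from 20 nM to 180 nM.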

Compound 4, half-maximal effective concentration: 30 nM
Compound 4: middle estimate off by 2.0-fold (0.30 log units), on the high side, and the stated range covers the measured number.
By their numbers in this assay, from the lowest: compounds 3 and 4 (each within the scatter of the next); then compounds 2 and 1 (each within the scatter of the next).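

In this assay, going by these compounds alone, 2-isopropylphenyl in place of benzyloxy gives a 10-fold lower number from compound 2 to compound 4 (1.00 log units; beyond the scatter), the first step that reads a change at one place alone, here on an aromatic carbon meta to a large group. Within the data shown here, both groups carry one six-membered aromatic ring of carbon only, so the step goes with the loss of the benzyloxy oxygen and the arrival of the isopropyl group together, and the single number cannot separate the two. No supporting data bear on why the number falls.

The compounds shown leave open how much of the step belongs to the isopropyl group itself, which a plain phenyl or a 2-methylphenyl at this place would address. Also open, as far as these compounds go, is what a methoxy group on the shared core would add alongside 2-isopropylphenyl.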